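The source may report more compounds than this note shows. Statements on the series, on what has been measured and on what is new or still open speak of the compounds shown alone.

Measured so far:
- compound 1 `Cc1cc(-c2cc(Cl)cc(C)c2/C=C/[C@@H]2C[C@@H](O)CC(=O)O2)ccc1F` — 6 nM
- compound 2 `Cc1cccc(-c2cc(Cl)cc(Cl)c2/C=C/[C@@H]2C[C@@H](O)CC(=O)O2)c1` — 16 nM

Both numbers come from an assay for inhibition of 3-hydroxy-3-methylglutaryl-coenzyme A reductase (Rattus norvegicus); on this read-out lower numbers stand for stronger inhibition and higher numbers for weaker inhibition. Compound 2 holds the highest of the two numbers; its nearest neighbour is compound 1, whose number is lower by a gap that lies beyond the usual scatter of this assay. Compound 1 and compound 2 differ in two places at once, so no single-change step can be read from them.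

Compound 3 `Cc1cc(F)ccc1-c1cc(Cl)cc(Cl)c1/C=C/[C@@H]1C[C@@H](O)CC(=O)O1` has not been measured in this assay. Relative to compound 2 the change is 4-fluoro-2-methylphenyl in place of 3-methylphenyl on an aromatic carbon. For the measured compounds named here, the group that enters is the one carried by compound 1, while the rest of compound 3 is that of compound 2, so compound 3 combines the aryl of compound 1 with the core of compound 2.

Because compound 1, which carries the same entering group, gives 6 nM, the expected direction of the step for compound 3 is towards a lower number, of modest size, a 1.8-fold lower number from compound 2 to compound 3 (0.25 log units; within the scatter). The estimate for compound 3 in this assay is 9 nM, within 4 nM to 25 nM.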

Compound 3, half-maximal inhibitory concentration: 36 nM
Estimate against measurement, compound 3: 4.0-fold (0.60 log units) below, and the stated range ends below it.
By their numbers in this assay, from the lowest: compound 1; then compound 2; then compound 3.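

In this assay, placing 4-fluoro-2-methylphenyl instead of 3-methylphenyl on this aromatic carbon, ortho to a large group and meta to two chloro groups, weakens inhibition, with a 2.3-fold higher number from compound 2 to compound 3 (0.35 log units; beyond the scatter), a modest step beyond the scatter. This single swap adds the fluorine and shifts the methyl together, so the step describes the two aryl groups as whole units, while steps to compound 1 cannot be read, as it differs from compound 2 and from compound 3 in more than one place. No measurement shown here accounts for the direction or size of this step.

The compounds shown leave open how the step divides between the fluorine and the methyl placement, which a plain 2-methylphenyl or 4-fluorophenyl on the core of compound 2 would help to separate. They also leave open whether the same swap runs in the same direction on the core of compound 1, and how this position responds to an aryl group carrying an amine or a carboxylic acid.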